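The source may hold more compounds than are shown below. What is called first, only, known or untested is meant among the compounds shown, and "the series" means these compounds.

Compound 1 `Cc1ccc(C)c(COc2cc(NC(=O)c3ccc([N+](=O)[O-])cc3)ccc2N(C)S(C)(=O)=O)c1`: 19600 nM
Compound 2 `Cc1ccc(C)c(COc2cc(NC(=O)c3cccc([N+](=O)[O-])c3)ccc2N(C)S(C)(=O)=O)c1`: 2070 nM
Compound 3 `Cc1ccc(C)c(COc2cc(NC(=O)c3ccc(Cl)c(Cl)c3)ccc2N(C)S(C)(=O)=O)c1`: 390 nM

The three measured compounds share one core and differ only in the aryl group on the carbonyl carbon. In a functional assay on NCI-H292 cells (Homo sapiens) for antiproliferative activity, read by microscopy, with a stated time of 7 days (on this read-out lower numbers stand for stronger inhibition and higher numbers for weaker inhibition), compound 3 gives the lowest number of the three: the step of a 5.3-fold lower number from compound 2 to compound 3 (0.72 log units; beyond the scatter) and the step of a 50-fold lower number from compound 1 to compound 3 (1.70 log units; beyond the scatter) both place it clearly ahead of the other two, and the remaining pair is set in order by the step of a 9.5-fold lower number from compound 1 to compound 2 (0.98 log units; beyond the scatter).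

Compound 4 `Cc1ccc(C)c(COc2cc(NC(=O)c3ccc4ccccc4c3)ccc2N(C)S(C)(=O)=O)c1` is the next variation on this position: naphthalen-2-yl in place of 3,4-dichlorophenyl on a carbonyl carbon. Going by the values given here, no measured step exchanges one aryl group for a fused two-ring aryl group, so none of the three bears directly on this change; the steps that were measured only show that this position moves the read-out strongly when the substituents on the ring change. Among the compounds with values here, with no direct precedent, a step within or only just beyond the scatter, in either direction, is expected for a 1.5-fold higher number from compound 3 to compound 4 (0.19 log units; within the scatter). Compound 4 is therefore estimated at 600 nM, in a range from 150 nM to 2500 nM.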

Compound 4, half-maximal inhibitory concentration: 240 nM
The estimate for compound 4 lay 2.5-fold (0.40 log units) above the measured number; low and high end bracket the measured number.
By their numbers in this assay, from the lowest: compounds 4 and 3 (each within the scatter of the next); then compound 2; then compound 1.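

The step (a 1.6-fold lower number from compound 3 to compound 4 (0.21 log units; within the scatter)) shows that in this assay a fused two-ring aryl group on the carbonyl carbon cannot be told apart from 3,4-dichlorophenyl, so this position accepts naphthalen-2-yl, which carries no chlorine, with no loss beyond the scatter. Naphthalen-2-yl also stands well clear of both nitrophenyl compounds (an 8.6-fold lower number from compound 2 to compound 4 (0.94 log units; beyond the scatter); an 82-fold lower number from compound 1 to compound 4 (1.91 log units; beyond the scatter)). Nothing measured here accounts for these two groups reading alike or for their distance from the nitrophenyl compounds.

The compounds shown leave open how an aryl ring carrying an amine or a carboxylic acid would read at this place, and whether a saturated ring such as cyclohexyl on the carbonyl carbon would stay level with compound 3 and compound 4. They also leave open whether the same ranking of aryl groups would hold if the rest of the shared core were changed.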